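A few compounds are considered here, and "the series" means these few. Any claim that something is new, unique, unknown or untested is made for them only; others in the source may bear on it.

Among the measured compounds shown here, in a functional assay on NC-37 cells (Homo sapiens) for cytotoxicity (a higher number here means that more compound is tolerated, a lower number that less compound is tolerated), compound 3 (`C[C@H]1[C@H](O)[C@@H](CO)O[C@H]1n1cc(F)c(N)nc1=O`) gives 0.22 ug/mL, the only actual number so far. Compound 1 (`C[C@H]1[C@H](O)[C@@H](CO)O[C@H]1n1cc(Cl)c(=O)[nH]c1=O`) gives > 100 ug/mL, which is a limit of the assay. Compound 2 (`C[C@H]1[C@H](O)[C@@H](CO)O[C@H]1n1cc(Br)c(=O)[nH]c1=O`) gives > 100 ug/mL, which is also a limit.

Compound 4 (`C[C@H]1[C@H](O)[C@@H](CO)O[C@H]1n1cc(Br)c(N)nc1=O`) departs from compound 3 by one change, bromo in place of fluoro on an aromatic carbon, ortho to an amino group. For the measured compounds named here, the one measured exchange of this kind is a step that the two limits leave unreadable from compound 1 to compound 2, so it offers no size to carry over. The closest guide is compound 2, which carries bromo as compound 4 does, but it differs from compound 3 in more than that one place. The result of compound 2, > 100 ug/mL, a limit, therefore gives only a loose hint of a shift towards more compound being tolerated.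

On that hint, the expected change is a 91-fold higher number from compound 3 to compound 4 (1.96 log units; beyond the scatter), a rise well beyond the scatter in this assay, though its size is uncertain. Compound 4 is estimated at 20 ug/mL, with a range from 1 ug/mL to 100 ug/mL.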

Compound 4, half-maximal cytotoxic concentration: > 100 ug/mL
Compound 4: a limit, no number (the forecaster's own chance of this, stated with the estimate: 40%); middle value at least 5.0-fold (0.69 log units) from the limit.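

At this place, on an aromatic carbon ortho to an amino group, the exchange of fluoro for bromo now has a readable size, which the earlier chloro and bromo pair could not give: in this assay the change brings an at least 450-fold higher number from compound 3 to compound 4 (2.65 log units; beyond the scatter). So in the compounds with the amino group, the single atom at this place separates a compound that is tolerated only at a low concentration from one that reaches the end of the measured range. The true size of the step may be larger still, since compound 4 stops at a limit and not at a number: the limit of > 100 ug/mL in this assay, at which 3 of the 4 values shown sit.

From the compounds shown here alone, whether a methyl or a nitrile group at this place would sit closer to compound 3 or to compound 4 remains open. Also open, going by these compounds, is how far past the limit compound 4 really lies.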